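Moving the Hydroxyl Group: From Compound 2 to Compound 3

A few compounds are considered here, and "the series" means these few. Any claim that something is new, unique, unknown or untested is made for them only; others in the source may bear on it.

For the measured compounds named here, compound 2 `CC(C)Cc1cnc(C(=O)/C=C/c2ccccc2O)cn1` gives 144000 nM in a functional assay on the whole organism for inhibition, with Spinacia oleracea as the target, read by spectrophotometry, with a stated time of 4 h (a higher number here means a weaker inhibitor, a lower number a stronger inhibitor), the lower of the two numbers measured so far. Compound 1 `CCCc1cnc(C(=O)/C=C/c2ccc(O)cc2)cn1` differs from it in two places and gives 399000 nM in this assay, a gap beyond the usual scatter. Compound 3 `CC(C)Cc1cnc(C(=O)/C=C/c2ccc(O)cc2)cn1` is compound 2 with one change: 4-hydroxyphenyl in place of 2-hydroxyphenyl on a double-bonded chain carbon bound to a double-bonded chain carbon. Compound 1 carries the same 4-hydroxyphenyl and shows the weaker 399000 nM, so weaker inhibition is expected for compound 3, although the second difference between compound 1 and compound 2 leaves this uncertain. The expected step is a 2.1-fold higher number from compound 2 to compound 3 (0.32 log units; beyond the scatter). Compound 3 is estimated at 300000 nM, within 120000 nM to 800000 nM.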

Compound 3, half-maximal inhibitory concentration: 235000 nM
For compound 3 the middle estimate is 1.3-fold (0.11 log units) above the measured one, and the stated range covers the measured number.
By their numbers in this assay, from the lowest: compounds 2, 3 and 1 (each within the scatter of the next, the first and the last beyond it).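

Swapping 2-hydroxyphenyl for 4-hydroxyphenyl on the double-bonded chain carbon gives a 1.6-fold higher number from compound 2 to compound 3 (0.21 log units; within the scatter) in this assay, so this assay does not separate these two placings of the hydroxyl group. Methyl in place of hydrogen on the saturated chain carbon gives a 1.7-fold lower number from compound 1 to compound 3 (0.23 log units; within the scatter) and likewise stays within the usual scatter. Nothing available here bears on why these numbers fall as they do.

As far as these compounds go, it remains open whether a methoxy group or an amine in place of the hydroxyl would shift the number beyond the scatter. A longer chain on the core is equally untested in the compounds shown.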